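Anilide chain series: replacing the hydrated trifluoromethyl end group

The compounds below may be only part of what the source reports. "The series", "measured", "known", "first", "only" and "open" are said of these compounds alone.

Of the compounds shown here, three have been measured in a functional assay on HCT-116 cells (Homo sapiens) for inhibition, read by colorimetric assay, with a stated time of 3 days; a lower number here means a stronger inhibitor, a higher number a weaker inhibitor. Compound 1 `O=C(CCCCCCNC(=O)C(O)(O)C(F)(F)F)Nc1cccc(Br)c1` gives 3060 nM in this assay. Compound 2 `O=C(CCCCCCCNC(=O)C(O)(O)C(F)(F)F)Nc1ccccc1` gives 41700 nM in this assay, the highest of the two numbers shown; its nearest neighbour is compound 1, which lies at a markedly lower number, beyond the scatter. Compound 3 `O=C(CCCCCCNC(=O)C(O)C(F)(F)F)Nc1nccs1` returns only a limit in this assay, namely > 40000 nM. Among the compounds with values here, no pair of measured compounds differs in one place only, so no single measured step can be isolated. The weak end of the range is marked by the limit of > 40000 nM in this assay, at which 1 of the 3 values shown sits.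

Compound 4 `O=C(CCCCCCCNC(=O)c1cc(=O)c(O)co1)Nc1ccccc1` has not yet been measured in this assay. It differs from compound 2 by a group of 8 heavy atoms (5 carbon, 3 oxygen; one six-membered aromatic ring with 1 hetero atom) in place of a group of 7 heavy atoms (2 carbon, 2 oxygen, 3 fluorine; no ring), on a carbonyl carbon. The chain and the anilide end are kept unchanged, so any movement in this assay must come from this exchange at the carbonyl carbon.

Without a measured step that bears on this exchange, no large shift is expected in either direction. Compound 4 is estimated at 50000 nM in this assay, between 12000 nM and 200000 nM. The step from compound 2 to compound 4 is thus expected to be a 1.2-fold higher number from compound 2 to compound 4 (0.08 log units; within the scatter), a change within the scatter, with a fair chance that only a limit is recorded.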

Compound 4, half-maximal inhibitory concentration: > 100000 nM
Compound 4: a limit, no number (the forecaster's own chance of this, stated with the estimate: 45%); middle value at least 2.0-fold (0.30 log units) away from the limit.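

In this assay, within the data shown here, the exchange of the 2,2,2-trifluoro-1,1-dihydroxyethyl group for the six-membered aromatic ring group on the carbonyl carbon gives an at least 2.3-fold higher number from compound 2 to compound 4 (0.37 log units; beyond the scatter), the first single-place step. With the chain and the anilide end unchanged, this shows that the exchange does not retain even the modest inhibition of compound 2, which stands at 41700 nM, so the 2,2,2-trifluoro-1,1-dihydroxyethyl group cannot be replaced by this ring group without a loss beyond the scatter. Compound 4 gives a limit and not a number, so the step sets only the smallest possible size of that loss: the limit of > 100000 nM in this assay, at which 1 of the 4 values shown sits.

On these data alone, the true size of the loss remains open, as does whether a carboxylic acid or a hydroxamic acid on the same carbonyl carbon would keep or improve on the level of compound 2. As far as these compounds go, compound 1 differs from compound 2 in more than one place, so it also remains open whether the ring group would fare differently with the shorter chain and a bromine on the anilide.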